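Propiolamide to crotonamide on the trimethoxyanilide series

The compounds below may be only part of what the source reports. "The series", "measured", "known", "first", "only" and "open" are said of these compounds alone.

Three members of the series have been run in a functional assay on HCT-116 cells (Homo sapiens) for inhibition, read by MTT assay, with a stated time of 48 h; a lower number here means a stronger inhibitor, a higher number a weaker inhibitor. Compound 1 `COc1ccc(CNc2cc(OC)c(OC)c(OC)c2)cc1[N+](=O)[O-]`, a secondary amine without an acyl group, gives 18200 nM. Compound 2 `C/C=C/C(=O)N(Cc1cc(OC)c(OC)c(OC)c1)c1ccc(OC)c(O)c1`, a (prop-1-en-1-yl)carbonyl amide, gives 8450 nM. Compound 3 `C#CC(=O)N(Cc1ccc(OC)c(O)c1)c1cc(OC)c(OC)c(OC)c1`, an ethynylcarbonyl amide, gives 310 nM, the lowest of the three numbers; the nearest is compound 2, beyond the scatter, and the furthest is compound 1, also beyond the scatter. No pair among these three differs in one place only, so no single step can be read from the measured set.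

Compound 4 `C/C=C/C(=O)N(Cc1ccc(OC)c(O)c1)c1cc(OC)c(OC)c(OC)c1` is the one-place neighbour of compound 3: prop-1-en-1-yl in place of ethynyl on a carbonyl carbon. It keeps the aryl arrangement of compound 3 and takes the acyl group found in compound 2.

Within this assay the only (prop-1-en-1-yl)carbonyl amide measured, compound 2, sits well above compound 3, but it differs in more than the acyl group, so it shows only its own value. A step toward a weaker inhibitor is expected, larger than the scatter, with the step from compound 3 to compound 4 estimated at an 8.1-fold higher number from compound 3 to compound 4 (0.91 log units; beyond the scatter). For compound 4 the expected value in this assay is 2500 nM, with a range from 600 nM to 10000 nM.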

Compound 4, half-maximal inhibitory concentration: 55 nM
Beside the measured number, compound 4's estimate is 45-fold (1.66 log units) above it, and the stated range ends above it.
By their numbers in this assay, from the lowest: compound 4; then compound 3; then compound 2; then compound 1.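

On a carbonyl carbon whose other neighbour is an amide-type nitrogen, the ethynyl group is not required for a low number in this assay: prop-1-en-1-yl in its place gives a 5.6-fold lower number from compound 3 to compound 4 (0.75 log units; beyond the scatter), a modest step beyond the scatter. For the compounds shown here, this is the first one-place step, and it leaves compound 4 at 55 nM as the lowest of the four numbers, so this position tolerates a change from a triple bond to a double bond with one more carbon. No measurement among these compounds bears on the reason for this step.

Going by these compounds, compounds 1 and 2 have no one-place partner here, so steps to them cannot be read, and whether the same exchange would hold on the aryl arrangement of compound 2 stays unknown. Also open, on these data alone, is how a saturated propyl group, a longer alkenyl chain or an amine on the acyl chain would compare with prop-1-en-1-yl at this position, since this single step cannot separate the effect of the bond type from that of the added carbon.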